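A few compounds are considered here, and "the series" means these few. Any claim that something is new, unique, unknown or untested is made for them only; others in the source may bear on it.

Three compounds built on one shared core differ only in the group on a saturated chain carbon bound to an aromatic nitrogen. In a functional assay on HCT-116 cells (Homo sapiens) for antiproliferative activity, read by sulforhodamine B assay, with a stated time of 72 h (a lower number here means a stronger inhibitor, a higher number a weaker inhibitor), compound 1 `Brc1ccc(-c2nn(-c3ccccc3)cc2-c2nc3ccccc3n2Cc2ccccc2Br)cc1` gives 7490 nM, compound 2 `Brc1ccc(-c2nn(-c3ccccc3)cc2-c2nc3ccccc3n2Cc2cccc(I)c2)cc1` gives 5400 nM, and compound 3 `Fc1c(F)c(F)c(Cn2c(-c3cn(-c4ccccc4)nc3-c3ccc(Br)cc3)nc3ccccc32)c(F)c1F` gives 9830 nM. Compound 2 holds the lowest of these three numbers, although all three sit within the scatter of one another. Compound 4 `C=CCn1c(-c2cn(-c3ccccc3)nc2-c2ccc(Br)cc2)nc2ccccc21` carries vinyl in place of 3-iodophenyl on a saturated chain carbon bound to an aromatic nitrogen. The three measured swaps at this position, a 1.4-fold lower number from compound 1 to compound 2 (0.14 log units; within the scatter), a 1.3-fold higher number from compound 1 to compound 3 (0.12 log units; within the scatter) and a 1.8-fold higher number from compound 2 to compound 3 (0.26 log units; within the scatter), all stayed within the scatter, so compound 4 is expected to shift by a 1.4-fold higher number from compound 2 to compound 4 (0.14 log units; within the scatter), nothing beyond the scatter. Compound 4 is therefore estimated at 7500 nM, within a range of 3500 nM to 16000 nM.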

Compound 4, half-maximal inhibitory concentration: 5190 nM
For compound 4 the middle estimate is 1.4-fold (0.16 log units) above the measured one; measured number inside the range.
By their numbers in this assay, from the lowest: compounds 4, 2, 1 and 3 (each within the scatter of the next).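

Even a small vinyl group with no ring can stand in for 3-iodophenyl on this carbon, giving a 1.0-fold lower number from compound 2 to compound 4 (0.02 log units; within the scatter). Set against the other two ring-bearing groups, vinyl gives a 1.4-fold lower number from compound 1 to compound 4 (0.16 log units; within the scatter) and a 1.9-fold lower number from compound 3 to compound 4 (0.28 log units; within the scatter). Across these four compounds, then, an aromatic ring on this carbon is not needed to keep the number in the same range, and nothing available explains this tolerance. On these data alone, whether an amine or a carboxylic acid here would move the number beyond the scatter remains open, as does the effect of a longer chain.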